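A few compounds are considered here, and "the series" means these few. Any claim that something is new, unique, unknown or untested is made for them only; others in the source may bear on it.

The measured compounds, all in a functional assay on PC-3 cells (Homo sapiens) for cytotoxicity, read by MTT assay, with a stated time of 72 h; a higher number here means a weaker inhibitor, a lower number a stronger inhibitor:

compound 1 `COc1ccc(S(=O)(=O)c2nc3ccccc3nc2N2CCCC2)cc1` gives > 50000 nM, which is a limit of the assay and not a number.
compound 2 `COc1ccc(S(=O)(=O)c2nc3ccccc3nc2N2CCCC(O)C2)cc1` gives 3410 nM.
compound 3 `Cc1ccc(S(=O)(=O)c2nc3ccccc3nc2N2CCC(O)CC2)cc1` gives 9520 nM.

Compound 3 has the highest of the two numbers that were obtained; compound 2, its nearest neighbour, sits lower, and the value of compound 1 is only a limit (the limit of > 50000 nM in this assay, at which 1 of the 3 values shown sits). Within the data shown here, the one step that can be read directly is an at least 14-fold lower number from compound 1 to compound 2 (1.16 log units; beyond the scatter), where the pyrrolidinyl of compound 1 is exchanged for a 3-hydroxypiperidinyl; it is a large step.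

Compound 4 `COc1ccc(S(=O)(=O)c2nc3ccccc3nc2N2CCC(O)CC2)cc1` differs from compound 3 in one place: methoxy in place of methyl on an aromatic carbon. Among the measured compounds shown here, no measured pair shows this exchange on its own; compound 2 and compound 3 differ both in the aryl substituent and in the hydroxypiperidine, so their values cannot be split into the two parts. Since the exchange changes nothing in the hydroxypiperidine and only alters a small group far from it, the step is expected to stay within the scatter, if anything slightly toward a lower number, as compound 2 with its methoxy gives 3410 nM. Compound 4 is therefore estimated at 7000 nM, in the range 2500 nM to 20000 nM, which means an expected step of a 1.4-fold lower number from compound 3 to compound 4 (0.13 log units; within the scatter).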

Compound 4, half-maximal inhibitory concentration: 9730 nM
Estimate against measurement, compound 4: 1.4-fold (0.14 log units) below, within the range that was stated.
By their numbers in this assay, from the lowest: compound 2; then compounds 3 and 4 (each within the scatter of the next). At a limit, above all of these: compound 1.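

In this assay, methoxy in place of methyl on an aromatic carbon can now be read on its own, and it leaves compound 3 and compound 4 within the scatter of each other (a 1.0-fold higher number from compound 3 to compound 4 (0.01 log units; within the scatter)). With the 4-methoxyphenyl held fixed, the position of the hydroxyl on the piperidine can also be read, and here the 3-hydroxypiperidin-1-yl gives the lower number, a modest step beyond the scatter (a 2.9-fold higher number from compound 2 to compound 4 (0.46 log units; beyond the scatter)). Compound 1 stands at a limit and not at a number, so an at least 5.1-fold lower number from compound 1 to compound 4 (0.71 log units; beyond the scatter) is only a bound, and it shows that the 4-hydroxypiperidin-1-yl, like the 3-hydroxypiperidin-1-yl, gives a measurable number where the pyrrolidin-1-yl does not: the limit of > 50000 nM in this assay, at which 1 of the 4 values shown sits.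

On these data alone, it remains open whether methoxy and methyl also sit within the scatter of each other on the 3-hydroxypiperidin-1-yl, and how a chlorine or a carboxylic acid would read in their place on the aromatic ring. As far as these compounds go, it is equally open whether an amine in place of the hydroxyl on the piperidine, or a hydroxyl on the pyrrolidine itself, would give a number near that of compound 2.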